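This account rests on a few compounds, and the source may have more. Where it says the series, first, only, none or still open, it means among the compounds named here.

Measured so far:
compound 1, `Cc1ccc(-n2cc(C(=O)Nc3cc(F)cc(F)c3)c(=O)c3ccc(N(C)C)nc32)cc1OCCCCCCC[N+]12CCN(CC1)CC2`, gives 9.71% in an assay on LX2 cells for inhibition of COL1A1 promoter (Homo sapiens), read by a luciferase reporter, with a stated time of 24 h, tested at 50 uM; a lower number here means a weaker effect, a higher number a stronger effect of the compound at the concentration tested;
compound 2, `Cc1ccc(-n2cc(C(=O)Nc3cc(F)cc(F)c3)c(=O)c3ccc(N(C)C)nc32)cc1OCCCCCCC[N+]1(C)CCCCC1`, gives 45.1% in this assay.

Compound 2 stands highest of the two numbers; its nearest neighbour is compound 1, and the step of a number 35.4 percentage points higher from compound 1 to compound 2 (beyond the scatter) lies beyond the scatter. Compound 3, `Cc1ccc(-n2cc(C(=O)Nc3cc(F)cc(F)c3)c(=O)c3ccc(N(C)C)nc32)cc1OCCCCCCC[n+]1ccccc1`, has not yet been measured. It differs from compound 2 by a group of 6 heavy atoms (5 carbon, 1 nitrogen; one six-membered aromatic ring with 1 hetero atom) in place of a group of 7 heavy atoms (6 carbon, 1 nitrogen; one six-membered non-aromatic ring with 1 hetero atom), on a saturated chain carbon, seven bonds along the chain from an oxygen on an aromatic ring. Going by the values given here, the one measured step, a number 35.4 percentage points higher from compound 1 to compound 2 (beyond the scatter), also changed the charged head at this same place on the chain, and was large, so a change of the head here can move the read-out strongly. Among the compounds with values here, no measured step shows the aromatic head itself, so the direction for compound 3 is open; a step of modest size in either direction is expected, a number 10.1 percentage points lower from compound 2 to compound 3 (beyond the scatter). On that basis compound 3 is estimated at 35% in this assay, in the range 8% to 62%.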

Compound 3, a percentage reported as inhibition, at one concentration (the size of the read-out at that concentration, not a potency): 22.2%
The estimate for compound 3 lay 12.8 percentage points above the measured number, and the stated range covers the measured number.
By their numbers in this assay, from the lowest: compound 1; then compound 3; then compound 2.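

Replacing the non-aromatic six-membered ring head with a six-membered aromatic ring, with net charge +1 on both, gives a number 22.9 percentage points lower from compound 2 to compound 3 (beyond the scatter) in this assay and so shows that keeping the charge at this place does not keep the read-out. The same aromatic head still gives a number 12.5 percentage points higher from compound 1 to compound 3 (beyond the scatter) and so sits in the middle, which means the heads shown here do not fall into just one good and one poor kind. Nothing measured here explains this order.

Going by these compounds, what a morpholine or a carboxylic acid would do at the end of this chain remains open. On these data alone, all three compounds share one chain and one core, so it is also open whether this order of heads would hold on a shorter or longer chain.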